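The source may hold more compounds than are shown below. What is called first, only, known or untested is meant among the compounds shown, and "the series" means these compounds.

Of the compounds shown here, two that share one core have been tested in a functional assay for inhibition of serine protease 1 (Homo sapiens), tested at 0.1 mM; on this read-out lower numbers stand for a weaker effect and higher numbers for a stronger effect at the one concentration tested. Compound 1 `CC(O)Cc1ccc2ccc(=O)oc2c1` carries a 2-hydroxypropyl group on that core, and in this assay compound 1 gives 29.3%. Compound 2 `O=c1ccc2ccc(/C=N/Nc3ccccc3)cc2o1` gives 31.4% in this assay. Compound 1 is the lower of the two numbers, yet its gap to compound 2 lies within the usual scatter, so the two cannot be told apart on this evidence.

Compound 3 `O=c1ccc2ccc(/C=N/O)cc2o1` has not yet been tested. It differs from compound 1 in one place (a group of 3 heavy atoms (1 carbon, 1 nitrogen, 1 oxygen; no ring) in place of a group of 4 heavy atoms (3 carbon, 1 oxygen; no ring), on an aromatic carbon). Among the measured compounds shown here, no measured pair differing in a single place is available, so the size of such a step is unknown here. The two measured numbers sit close together, and nothing in them points to a different level for a third variation of the same core. The change is therefore expected to bring no step beyond the scatter a number 1.3 percentage points lower from compound 1 to compound 3 (within the scatter). Compound 3 is estimated at 28%, within a range from 10% to 48%.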

Compound 3, a percentage reported as inhibition, at one concentration (the size of the read-out at that concentration, not a potency): 20.3%
Estimate against measurement, compound 3: 7.7 percentage points above; measured number inside the range.
By their numbers in this assay, from the lowest: compounds 3, 1 and 2 (each within the scatter of the next, the first and the last beyond it).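

Among the compounds shown here, compound 1 and compound 3 give the first step that can be read at this aromatic carbon, and in this assay it is a number 9 percentage points lower from compound 1 to compound 3 (within the scatter). Replacing the 2-hydroxypropyl group with the smaller group of 3 heavy atoms, which brings a double bond outside the aromatic rings and one more hydrogen-bond acceptor, therefore produces no change that can be told apart from repeat-to-repeat variation at the one concentration tested. No other measurement is available to help interpret this result.

A single exchange at one position says little about how much this carbon can tolerate. An amine, a carboxylic acid or a longer chain at the same place might still shift the number beyond the scatter, and the single-concentration read-out gives no potency for any of these compounds.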